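Swapping pyridin-4-yl for 4-chlorophenyl on a carbonyl carbon

The source may hold more compounds than are shown below. What is called first, only, known or untested is meant among the compounds shown, and "the series" means these compounds.

Compound 1 `COc1ccc(-c2cnc(NC(=O)c3cccc(Cl)c3)n2C)cc1`: > 28000 nM
Compound 2 `COc1ccc(-c2cnc(NC(C)=O)n2C)cc1`: > 100000 nM
Compound 3 `COc1ccc(-c2cnc(NC(=O)c3ccncc3)n2C)cc1`: > 100000 nM

In a toxicity assay on THP-1 cells (Homo sapiens) for inhibition (a higher number here means that more compound is tolerated, a lower number that less compound is tolerated), the three measured compounds end in limits and not in numbers. Compound 3 gives > 100000 nM, which is a limit. That is the limit of > 100000 nM in this assay, at which 2 of the 3 values shown sit. The lone remaining result is the limit of > 28000 nM in this assay, at which 1 of the 3 values shown sits.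

Compound 4 `COc1ccc(-c2cnc(NC(=O)c3ccc(Cl)cc3)n2C)cc1` keeps the shared core and differs from compound 3 on a carbonyl carbon, with 4-chlorophenyl in place of pyridin-4-yl on a carbonyl carbon.

The closest measured change is a step that the two limits leave unreadable from compound 1 to compound 3, which puts pyridin-4-yl in place of 3-chlorophenyl at that same carbon. The other two changes at this carbon, a step that the two limits leave unreadable from compound 1 to compound 2 and a step that the two limits leave unreadable from compound 2 to compound 3, give no size either. For the measured compounds named here, no measured step therefore supplies a size to carry over.

The expectation rests on compound 1, a chlorophenyl amide with > 28000 nM, which is a limit. In this assay a result for compound 4 is expected to be a limit again, or a number lying toward less compound tolerated. The expected change is an at least 2.5-fold lower number from compound 3 to compound 4 (0.39 log units; beyond the scatter). The estimate for compound 4 is 40000 nM, with an expected range from 15000 nM to 100000 nM.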

Compound 4, half-maximal cytotoxic concentration: > 100000 nM
Compound 4 was reported as a limit; the forecaster's own chance of this, stated with the estimate: 75%; middle value at least 2.5-fold (0.39 log units) away from the limit.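

In this assay compound 4 gives > 100000 nM, which is a limit. For the compounds shown here, all four results are limits, so no step from compound 1, compound 2 or compound 3 to compound 4 can be read. The compounds shown leave open how much of each is tolerated, and whether 4-chlorophenyl and 3-chlorophenyl on a carbonyl carbon differ at all.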